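Chloro to Bromo on an Aryl Ring of a Bile Acid Receptor Agonist

A few compounds are considered here, and "the series" means these few. Any claim that something is new, unique, unknown or untested is made for them only; others in the source may bear on it.

Measured compounds:
compound 1 `COc1ccc(C2SC(C)C(=O)Nc3c2c(C)nn3-c2ccccc2C)c(OC)c1`, 63%
compound 2 `Cc1nn(-c2ccccc2Cl)c2c1C(c1ccc(Oc3ccccc3)cc1)SC(C)C(=O)N2`, 57%

In an assay on isolated protein for agonist activity at Bile acid receptor (Homo sapiens), read by AlphaScreen, with a stated time of 30 min (a lower number here means a smaller maximal response, a higher number a larger maximal response), compound 1 gives 63% and compound 2 gives 57%; the gap between them lies within the usual scatter, so the two stand level. Compound 3 `Cc1nn(-c2ccccc2Br)c2c1C(c1ccc(Oc3ccccc3)cc1)SC(C)C(=O)N2` has not yet been measured in this assay. The change from compound 2 to compound 3 is bromo in place of chloro on an aromatic carbon. With nothing in the measured pair to suggest otherwise, the expected step from compound 2 to compound 3 is no change at the digits printed from compound 2 to compound 3 (within the scatter), none beyond the scatter. Compound 3 is estimated at 57%, from 42% to 72%.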

Compound 3, largest response reached (reported as efficacy), in percent of the reference or control that the assay uses: 84%
Compound 3: the middle estimate sits 27 percentage points below what was measured; the measured number lies above the stated range.
By their numbers in this assay, from the lowest: compounds 2 and 1 (each within the scatter of the next); then compound 3.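

In this assay, bromo in place of chloro gives a number 27 percentage points higher from compound 2 to compound 3 (beyond the scatter), so this aromatic carbon, ortho to a large group, does not treat the two halogens alike. The earlier pair differed in more than one place and could not show this. Nothing available accounts for the rise.

Going by these compounds, what an amine or a carboxylic acid would do on this carbon remains open. So does whether the same exchange would give a similar step with other groups on the shared core.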